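The source may hold more compounds than are shown below. What is called first, only, known or untested is meant among the compounds shown, and "the series" means these compounds.

The compounds here share one core and are compared in a functional assay on MCF7 cells (Homo sapiens) for inhibition, read by sulforhodamine B assay, with a stated time of 48 h; a higher number here means a weaker inhibitor of growth, a lower number a stronger inhibitor of growth. Compound 1, `O=C(Nc1ccccc1OC(F)(F)F)Nc1n[nH]c2ccccc12`, gives 1750 nM in this assay. Compound 2, `O=C(Nc1ccc(Cc2ccccc2)cc1)Nc1nn(C(=O)Nc2ccc(Cc3ccccc3)cc2)c2ccccc12`, is the largest of the set. In this assay compound 2 reaches only a limit, > 100000 nM, so no number is known for it (the limit of > 100000 nM in this assay, at which 1 of the 3 values shown sits). Compound 3, `Nc1nn(C(=O)Nc2ccc(Cc3ccccc3)cc2)c2ccccc12`, is smaller than compound 2, and in this assay compound 3 gives 555 nM. Of the two numbers in hand, that of compound 3 is the lower, and its distance from compound 1 lies beyond the usual scatter of repeated measurements.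

Compound 4, `CCCCOc1ccc(NC(=O)n2nc(N)c3ccccc32)cc1`, differs from compound 3 in a single place: butoxy in place of benzyl on an aromatic carbon. Among the measured compounds shown here, no pair of measured compounds shows what this exchange does, so there is no measured step to lean on, and the surrounding numbers give no direction. The expected step of a 1.3-fold higher number from compound 3 to compound 4 (0.10 log units; within the scatter) is therefore taken as no change beyond the scatter. Compound 4 is expected to give about 700 nM in this assay, with a likely range from 250 nM to 2500 nM.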

Compound 4, concentration for 50% growth inhibition: 14500 nM
Beside the measured number, compound 4's estimate is 21-fold (1.32 log units) below it; the whole stated range lies below it.
By their numbers in this assay, from the lowest: compound 3; then compound 1; then compound 4. At a limit, above all of these: compound 2.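

In this assay, among the compounds shown here, the exchange of benzyl for butoxy on this aromatic carbon, para to a large group, gives the first measured step at this place, and it is a large one: a 26-fold higher number from compound 3 to compound 4 (1.42 log units; beyond the scatter). This shows that the group at this position is far from interchangeable, since a chain of similar size cannot simply stand in for benzyl without a clear loss of growth inhibition, and the estimate of little change does not hold for this pair. The exchange removes an aromatic ring of carbon and brings in an open chain with an oxygen and a hydrogen-bond acceptor, but nothing measured here bears on which of these differences accounts for the step.

The compounds shown leave open whether the loss follows the departing ring or the entering oxygen, and a benzyloxy group, which keeps a ring and adds an oxygen, or a pentyl chain, which has neither, would pull these two apart. They also leave open how a short methoxy group or an amine would fare at this same place.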